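A few compounds are considered here, and "the series" means these few. Any claim that something is new, unique, unknown or untested is made for them only; others in the source may bear on it.

Compound 1 `C#CCn1cc(C(=O)NCCCOC(=O)[C@H]2CCCN2C(=O)OC(C)(C)C)c(=O)c2ccc(Cl)nc21` was tested in a functional assay on SW-620 cells (Homo sapiens) for cytotoxicity, read by MTT assay, with a stated time of 72 h; on this read-out higher numbers stand for weaker inhibition and lower numbers for stronger inhibition. In this assay compound 1 gives > 10000 nM, which is a limit of the assay and not a number. Compound 2 `C#CCn1cc(C(=O)NCCCOC(=O)[C@H](C)NC(=O)OC(C)(C)C)c(=O)c2ccc(Cl)nc21` shares the core of compound 1 and differs only by 1-((tert-butoxycarbonyl)amino)ethyl in place of 1-(tert-butoxycarbonyl)pyrrolidin-2-yl on a carbonyl carbon. In this assay compound 2 gives > 10000 nM, again a limit of the assay. The step that the two limits leave unreadable from compound 1 to compound 2 is therefore of unknown size. Both measured values sit at the limit of > 10000 nM in this assay, at which 2 of the 2 values shown sit.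

Compound 3 `C#CCn1cc(C(=O)NCCCOC(=O)[C@H]2CCCN2C(=O)OC(C)(C)C)c(=O)c2ccc(C)nc21` differs from compound 1 by methyl in place of chloro on an aromatic carbon of a six-membered aromatic ring with 1 nitrogen, part of a fused or bridged system of two rings, next to the ring nitrogen, meta to a fused ring, para to a fused ring. Within the data shown here, no measured step touches this position, and the single measured step leaves its size unreadable, so no step beyond the scatter is expected in either direction. Compound 3 is expected to give 15000 nM in this assay, within a range from 5000 nM to 50000 nM, most likely again reported as a limit. The implied step that the limit leaves unreadable from compound 1 to compound 3 is expected to stay unreadable against that limit.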

Compound 3, half-maximal inhibitory concentration: > 10000 nM
Compound 3 ended at the assay's limit (the forecaster's own chance of this, stated with the estimate: 80%); the middle value is on the limit's open side.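

In this assay no step can be read between compound 1 and compound 3, since both results are limits of the assay and not numbers: the limit of > 10000 nM in this assay, at which 3 of the 3 values shown sit.

The compounds shown leave open how strongly any of them acts on these cells, and whether methyl in place of chloro changes that at all.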